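A few compounds are considered here, and "the series" means these few. Any claim that something is new, unique, unknown or untested is made for them only; others in the source may bear on it.

Compound 1, `C=C[C@@]1(O)[C@@H](CO)O[C@@H](n2ccc(=O)[nH]c2=O)[C@@H]1O`, in a functional assay on KB cells (Homo sapiens), read by MTT assay (on this read-out higher numbers stand for weaker inhibition and lower numbers for stronger inhibition), gives 51800 nM. Compound 2, `C#CC[C@]1(O)[C@@H](CO)O[C@@H](n2ccc(=O)[nH]c2=O)[C@@H]1O`, reaches only a limit in this assay, > 350000 nM. Compound 3, `CC[C@@]1(O)[C@@H](CO)O[C@@H](n2ccc(N)nc2=O)[C@@H]1O`, gives 258000 nM.

Of the two values that are numbers rather than limits, compound 1 has the lower one, and the gap up to compound 3 lies beyond the usual scatter. Compound 4, `CCC#C[C@@]1(O)[C@@H](CO)O[C@@H](n2ccc(=O)[nH]c2=O)[C@@H]1O`, is not yet measured. It differs from compound 1 in one place: but-1-yn-1-yl in place of vinyl on a saturated ring carbon. Among the compounds with values here, no step between measured compounds is available to size this change, and compound 2, the one other alkyne, sits at the limit (the limit of > 350000 nM in this assay, at which 1 of the 3 values shown sits). For compound 4 a weakening is expected, a step of a 4.8-fold higher number from compound 1 to compound 4 (0.68 log units; beyond the scatter). The estimated value for compound 4 is 250000 nM, between 60000 nM and 1000000 nM.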

Compound 4, half-maximal inhibitory concentration: 226000 nM
Compound 4: middle estimate off by 1.1-fold (0.04 log units), on the high side, within the range that was stated.
By their numbers in this assay, from the lowest: compound 1; then compounds 4 and 3 (each within the scatter of the next). At a limit, above all of these: compound 2.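

Swapping vinyl for but-1-yn-1-yl on this saturated ring carbon gives, in this assay, a 4.4-fold higher number from compound 1 to compound 4 (0.64 log units; beyond the scatter), so activity here does respond to the group at this position. Compound 4 still gives a real number, so an alkyne directly on this carbon does not push the value to the end of the measurable range. Compound 2, the other alkyne, offers only a limit: the limit of > 350000 nM in this assay, at which 1 of the 4 values shown sits.

On these data alone, whether the loss follows the triple bond or the longer chain stays open. An ethynyl group on the core of compound 1 would separate the two.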